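The compounds below may be only part of what the source reports. "The series", "measured", "known", "first", "only" and "open" are said of these compounds alone.

Of the compounds shown here, three sharing one core have been measured in a physicochemical assay for lipophilicity; on this read-out higher numbers stand for higher lipophilicity and lower numbers for lower lipophilicity. Compound 1 `COC(=O)/C=C(C)/C=C/CC(C)CCCC(C)(C)OC` gives 5, compound 2 `C=CCOC(=O)/C=C(C)/C=C/CC(C)CCCC(C)(C)OC` gives 5.53, and compound 3 `COC(C)(C)CCCC(C)C/C=C/C(C)=C/C(=O)SC` gives 6.24, the highest of the three. The change that made compound 3 stand out is methylsulfanyl in place of methoxy on a carbonyl carbon, seen in a number 1.24 log units higher from compound 1 to compound 3 (beyond the scatter); a smaller rise came from vinyl in place of hydrogen in a number 0.53 log units higher from compound 1 to compound 2 (beyond the scatter). Compound 4 `CCN(CC)C(=O)/C=C(C)/C=C/CC(C)CCCC(C)(C)OC` differs from compound 3 by diethylamino in place of methylsulfanyl on a carbonyl carbon. Going by the values given here, no measured step places a nitrogen on that carbonyl carbon. A fall beyond the scatter is expected because a number 1.24 log units higher from compound 1 to compound 3 (beyond the scatter) shows how much the methylsulfanyl group added, softened by the four carbons that enter, giving a number 0.94 log units lower from compound 3 to compound 4 (beyond the scatter). Compound 4 is estimated at 5.3, between 4.7 and 5.9.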

Compound 4, partition coefficient: 4.82
Estimate against measurement, compound 4: 0.48 log units above, within the range that was stated.
By their numbers in this assay, from the lowest: compounds 4 and 1 (each within the scatter of the next); then compound 2; then compound 3.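

Going by these compounds alone, with diethylamino, this carbonyl carbon carries a nitrogen, which none of the earlier compounds has there. In this assay, that change gives a number 1.42 log units lower from compound 3 to compound 4 (beyond the scatter) and a number 0.71 log units lower from compound 2 to compound 4 (beyond the scatter). Set against methoxy, it gives a number 0.18 log units lower from compound 1 to compound 4 (within the scatter), so on this read-out the diethylamino group, with its four carbons, cannot be told apart from methoxy at this position.

Nothing available here explains these steps. Going by these compounds, whether dimethylamino or dipropylamino on the same carbonyl carbon would give numbers in line with diethylamino remains open.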